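Ethyl for methyl on the nitro-bearing core

The source may report more compounds than this note shows. Statements on the series, on what has been measured and on what is new or still open speak of the compounds shown alone.

Compound 1, `CCn1c(/C=C2/C(=O)Nc3ccccc32)nc2ccccc21`: 38000 nM
Compound 2, `Cn1c(/C=C2/C(=O)Nc3ccc([N+](=O)[O-])cc32)nc2ccccc21`: > 50000 nM

In a functional assay on PC-3 cells (Homo sapiens) for cytotoxicity, read by MTT assay, with a stated time of 48 h (a lower number here means a stronger inhibitor, a higher number a weaker inhibitor), compound 1 gives 38000 nM. For compound 2 the assay returns only a limit, > 50000 nM, which is the limit of > 50000 nM in this assay, at which 1 of the 2 values shown sits. Compound 2 thus stands at the upper edge of what the assay reports, with no number of its own. Compound 3, `CCn1c(/C=C2/C(=O)Nc3ccc([N+](=O)[O-])cc32)nc2ccccc21`, differs from compound 2 by methyl in place of hydrogen on a saturated chain carbon bound to an aromatic nitrogen. Within the data shown here, no measured pair shows the effect of this change, so the step from compound 2 to compound 3 is expected to stay within the scatter, a number no higher from compound 2 to compound 3 (the limit leaves the size open). Compound 3 is expected near 50000 nM, between 25000 nM and 150000 nM, and may again be reported only as a limit.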

Compound 3, half-maximal inhibitory concentration: 40100 nM
Compound 3: middle estimate off by 1.2-fold (0.10 log units), on the high side; the measured number falls inside the stated range.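

With ethyl on the aromatic nitrogen held in common, nitro in place of hydrogen on an aromatic carbon gives a 1.1-fold higher number from compound 1 to compound 3 (0.02 log units; within the scatter) in this assay, so this change shows no effect beyond the scatter. Methyl in place of hydrogen on the chain carbon bound to the aromatic nitrogen gives an at least 1.2-fold lower number from compound 2 to compound 3 (0.09 log units; that floor lies within the scatter). The value of compound 2 is only a limit, so this step has a floor but no size: the limit of > 50000 nM in this assay, at which 1 of the 3 values shown sits.

As far as these compounds go, whether a longer chain such as propyl on that nitrogen, or an amine in place of the nitro group, would move the number beyond the scatter remains open.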